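Halogenated aryl amine in a hepatocyte stability series

The source may hold more compounds than are shown below. What is called first, only, known or untested is meant among the compounds shown, and "the series" means these compounds.

Compound 1 `COc1cc(N(CC2CC2)c2ccccc2)cnc1C(=O)[C@H]1C[C@@H]1C(=O)O`: 3 uL/min
Compound 2 `CCN(c1cccc(C(F)(F)F)c1)c1cnc(C(=O)[C@H]2C[C@@H]2C(=O)O)c(OC)c1`: 3.1 uL/min

In an ADME assay on cells (Hepatocyte, Homo sapiens) for metabolic stability, read by LC-MS, with a stated time of 60 min, tested at 1 uM (on this read-out higher numbers stand for fast clearance and lower numbers for slow clearance), compound 1 gives 3 uL/min, the lower of the two numbers recorded, while compound 2 gives 3.1 uL/min; the gap between compound 1 and compound 2 lies within the usual scatter, so nothing separates them on this read-out. Both compounds share the same core and both are cleared slowly.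

Compound 3 `COc1cc(N(CC2CC2)c2cc(Cl)c(F)cc2F)cnc1C(=O)[C@H]1C[C@@H]1C(=O)O` is not yet measured in this assay. It differs from compound 1 in one place: 5-chloro-2,4-difluorophenyl in place of phenyl on a nitrogen on an aromatic ring. Two measured compounds give no guide to how a change on this nitrogen moves the read-out, so the expectation rests on the low numbers of compound 1 and compound 2 alone. The step from compound 1 to compound 3 is expected to be small, a 1.2-fold higher number from compound 1 to compound 3 (0.07 log units; within the scatter), and not beyond the scatter. Compound 3 is therefore estimated at 3.5 uL/min, in a range from 1.5 uL/min to 8 uL/min.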

Compound 3, intrinsic clearance in a liver preparation (reported as CLH), per the amount of preparation that the assay uses in the Hepatocyte assay: < 1.5 uL/min
Compound 3 gave a limit, no number (the forecaster's own chance of this, stated with the estimate: 15%); middle value at least 2.3-fold (0.36 log units) away from the limit.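

In the Hepatocyte assay compound 3 gives < 1.5 uL/min, which is a limit of the assay and not a number. Placing 5-chloro-2,4-difluorophenyl in place of phenyl on this nitrogen gives an at least 2.0-fold lower number from compound 1 to compound 3 (0.30 log units; that floor lies within the scatter), so the position accepts the added halogens without any rise in clearance, though the full size of the step cannot be read. In a physicochemical assay for lipophilicity, read by LC-MS, in phosphate buffer, measured as octanol-water partition, at pH 7.4 (on this read-out lower numbers stand for lower lipophilicity and higher numbers for higher lipophilicity), compound 1 gives 0.65 and compound 3 gives 1.1, so the clearance number in the Hepatocyte assay did not climb along with this higher distribution coefficient.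

The compounds shown do not tell whether the chlorine or the fluorines carry the step, as compound 3 brings them in together. Going by these compounds, how a single fluorine, a nitrile or an amine on this phenyl would read also stays open.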